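Swapping chloro for methoxy on the thiourea aryl ring

The source may hold more compounds than are shown below. What is called first, only, known or untested is meant among the compounds shown, and "the series" means these compounds.

Compound 1 `NC(=O)c1c(NC(=O)c2ccccc2I)sc2c1CCN(C(=S)Nc1ccccc1Cl)C2` gives 17500 nM in a functional assay on MKN-74 cells (Homo sapiens) for antiproliferative activity, with a stated time of 24 h (a higher number here means a weaker inhibitor, a lower number a stronger inhibitor), the highest of the three numbers, though all sit within the scatter. Compound 2 `Cc1ccccc1C(=O)Nc1sc2c(c1C(N)=O)CCN(C(=S)Nc1ccccc1Cl)C2` gives 11000 nM and compound 3 `Cc1ccc(C(=O)Nc2sc3c(c2C(N)=O)CCN(C(=S)Nc2ccccc2Cl)C3)cc1` gives 11300 nM; the steps of a 1.6-fold lower number from compound 1 to compound 2 (0.20 log units; within the scatter), a 1.5-fold lower number from compound 1 to compound 3 (0.19 log units; within the scatter) and a 1.0-fold higher number from compound 2 to compound 3 (0.01 log units; within the scatter) all concern the benzamide side. Compound 4 `COc1ccccc1NC(=S)N1CCc2c(sc(NC(=O)c3ccccc3I)c2C(N)=O)C1` differs from compound 1 by methoxy in place of chloro on an aromatic carbon. For the measured compounds named here, no measured step touches this part of the molecule, so the only guide is that every step so far stayed within the scatter. The expected step is therefore none beyond the scatter: compound 4 is estimated at 15000 nM, with a range of 6000 nM to 40000 nM, meaning a 1.2-fold lower number from compound 1 to compound 4 (0.07 log units; within the scatter).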

Compound 4, half-maximal inhibitory concentration: 41800 nM
Beside the measured number, compound 4's estimate is 2.8-fold (0.45 log units) below it; the whole stated range lies below it.
By their numbers in this assay, from the lowest: compounds 2, 3 and 1 (each within the scatter of the next); then compound 4.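

In this assay, for the compounds shown here, methoxy in place of chloro on the thiourea aryl ring gives a 2.4-fold higher number from compound 1 to compound 4 (0.38 log units; beyond the scatter), a modest weakening and the only step here beyond the scatter. Going by these compounds alone, the benzamide changes linking compounds 1, 2 and 3 all stayed within the scatter, so this aryl position is the first place where a single swap registers. Nothing available explains the rise.

Going by these compounds, whether the same swap would weaken compound 2 or compound 3 remains open. So does how a fluoro, a hydroxy or an amine at this position would compare.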